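Phenolic methylation in a nitrooxyalkyl cinnamate series

A few compounds are considered here, and "the series" means these few. Any claim that something is new, unique, unknown or untested is made for them only; others in the source may bear on it.

Three members of the series have been tested in a functional assay on SKBR cells (Homo sapiens) for cytotoxicity, read by resazurin assay, with a stated time of 72 h; on this read-out higher numbers stand for weaker inhibition and lower numbers for stronger inhibition. Compound 1 `COc1cc(/C=C/C(=O)OC/C=C/CO[N+](=O)[O-])ccc1O` gives 6530 nM. Compound 2 `O=C(/C=C/c1ccc(OCCCCO[N+](=O)[O-])c(O)c1)OCCCCO[N+](=O)[O-]` gives 3230 nM, the lowest number of the three and therefore the strongest inhibitor recorded so far; its gap to compound 1 is beyond the scatter, and its gap to compound 3 is wider still. Compound 3 `O=C(/C=C/c1ccc(OCCCCCCO[N+](=O)[O-])c(O)c1)OCCCCCCO[N+](=O)[O-]` gives 39700 nM, the weakest of the set. Among the measured compounds shown here, compounds 2 and 3 differ in more than one place, so no single step is drawn between them; the two numbers simply show the direction.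

The next compound, compound 4 `COc1cc(/C=C/C(=O)OCCCCO[N+](=O)[O-])ccc1OCCCCO[N+](=O)[O-]`, is compound 2 with one change: methyl in place of hydrogen on an oxygen on an aromatic ring. For the measured compounds named here, no measured pair isolates that change, so its size is unknown. Compound 1 carries the methoxy already, together with a different ester chain, and sits at a higher number than compound 2, but that comparison is confounded by the chain.

A small step is expected from compound 2 to compound 4, most likely toward a higher number though possibly none beyond the scatter, written as a 1.5-fold higher number from compound 2 to compound 4 (0.19 log units; within the scatter). Compound 4 is estimated at 5000 nM in this assay, within 2000 nM to 15000 nM.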

Compound 4, half-maximal inhibitory concentration: > 50000 nM
Compound 4: only a limit was reported; the forecaster's own chance of this, stated with the estimate: 5%; middle value at least 10-fold (1.00 log units) away from the limit.
By their numbers in this assay, from the lowest: compound 2; then compound 1; then compound 3. At a limit, above all of these: compound 4.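

In this assay compound 4 gives > 50000 nM, which is a limit of the assay and not a number. Methyl in place of hydrogen on an oxygen on an aromatic ring, the hydroxy to methoxy change, gives an at least 15-fold higher number from compound 2 to compound 4 (1.18 log units; beyond the scatter), so this single position carries a large effect on the read-out, which no earlier pair could show, and a free hydroxy here goes with the stronger inhibition in this one matched pair. The step is a bound and not a measured size, and compound 4 is the only member of the series recorded this way: the limit of > 50000 nM in this assay, at which 1 of the 4 values shown sits.

The compounds shown leave open whether the same change costs as much on the hexyl-type chain of compound 3 or the unsaturated ester chain of compound 1, since this is one pair on one chain length in one cell line. They also leave open whether the loss follows from capping this oxygen in general or from methyl in particular, which an ethyl ether, an acetate ester or an amino group in place of the hydroxy would begin to separate.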